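Notes on sulfonyl substituents: compound 3 to compound 4

A few compounds are considered here, and "the series" means these few. Any claim that something is new, unique, unknown or untested is made for them only; others in the source may bear on it.

Values measured in an ADME assay on CHO cells (Cricetulus griseus) for cytotoxicity, read by MTT assay (a higher number here means a weaker inhibitor, a lower number a stronger inhibitor), are as follows:
- compound 1 `O=S(=O)(CCO)c1cccc(-c2ccc3nccc(-c4ccncc4)c3n2)c1` gives 26000 nM
- compound 2 `O=S(=O)(c1cccc(-c2ccc3nccc(-c4ccncc4)c3n2)c1)N1CCC(O)CC1` gives 8000 nM
- compound 3 `O=S(=O)(c1cccc(-c2ccc3nccc(-c4ccncc4)c3n2)c1)N1CC[C@H](O)C1` gives 9000 nM

Compound 3 stands with compound 2 in the lower part of this short range. The separation from the hydroxyethyl sulfone is a 2.9-fold lower number from compound 1 to compound 3 (0.46 log units; beyond the scatter), while the comparison between the two ring compounds gives a 1.1-fold higher number from compound 2 to compound 3 (0.05 log units; within the scatter) and so does not separate them.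

The next compound is compound 4 `C[C@@H]1CN(S(=O)(=O)c2cccc(-c3ccc4nccc(-c5ccncc5)c4n3)c2)C[C@H](C)N1`, still to be measured. The change is 3,5-dimethylpiperazin-1-yl in place of 3-hydroxypyrrolidin-1-yl on a sulfonyl sulfur.

Two kinds of measured step bear on this. Placing a ring on the sulfur gave modest movement toward lower numbers, seen also in a 3.3-fold lower number from compound 1 to compound 2 (0.51 log units; beyond the scatter), but that step started from a non-ring group. Among the compounds with values here, the one exchange of ring for ring is the closer parallel, and it stayed within the scatter. Within the data shown here, no measured compound carries the entering group, so the range must stay wide.

No step beyond the scatter is expected in this assay, with a slight lean toward a lower number. The expected step is a 1.5-fold lower number from compound 3 to compound 4 (0.18 log units; within the scatter) as estimated here. Compound 4 is estimated at 6000 nM, with an expected range of 2000 nM to 15000 nM as the limits of this estimate.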

Compound 4, half-maximal inhibitory concentration: 6000 nM
Beside the measured number, compound 4's estimate shows no gap at the digits printed, and the stated range covers the measured number.
By their numbers in this assay, from the lowest: compounds 4, 2 and 3 (each within the scatter of the next); then compound 1.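

In this assay, the ring-for-ring exchange on the sulfonyl sulfur stays within the scatter even when 3,5-dimethylpiperazin-1-yl, which carries no oxygen, enters: a 1.5-fold lower number from compound 3 to compound 4 (0.18 log units; within the scatter) and a 1.3-fold lower number from compound 2 to compound 4 (0.12 log units; within the scatter) leave compound 4 unseparated from compound 2 and compound 3, so among these compounds a hydroxyl on the ring is not required for a number in this region. The separation from the open-chain group also holds for this third ring, at a 4.3-fold lower number from compound 1 to compound 4 (0.64 log units; beyond the scatter), so compound 2, compound 3 and compound 4 all lie apart from compound 1, with no compound shown going against that pattern, though the size of the step remains modest. Nothing available gives a reason for either observation.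

Every ring compound here also places a ring nitrogen on the sulfur, so the contribution of the ring cannot be told apart from that of the nitrogen, and an open-chain dimethylamino group on the sulfur would bear directly on this. As far as these compounds go, it also remains open whether the range of ring compounds extends to a morpholine or to a piperazine bearing a carboxylic acid.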